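Swapping Chloro for Bromo on a Fused Two-Ring Core

The source may hold more compounds than are shown below. What is called first, only, known or untested is meant among the compounds shown, and "the series" means these compounds.

The starting point is compound 1 `O=Cc1cccc(OCc2cn(Cc3ccccc3)nn2)c1`, a small aldehyde carrying the side chain shared by the whole set. In a functional assay on MDA-MB-231 cells (Homo sapiens) for inhibition, read by MTT assay, with a stated time of 48 h (a lower number here means a stronger inhibitor, a higher number a weaker inhibitor), compound 1 gives > 50000 nM, which is a limit of the assay rather than a number. Compound 2 `O=C1Nc2ccc(Cl)cc2/C1=C/c1cccc(OCc2cn(Cc3ccccc3)nn2)c1` joins that same side chain to a fused two-ring core bearing a chloro group. In this assay compound 2 has "not determined" (no result reported), so no single number places it; of the two values shown, one sits at the limit of > 50000 nM in this assay, at which 1 of the 2 values shown sits. Compound 3 `O=C1Nc2ccc(Br)cc2/C1=C/c1cccc(OCc2cn(Cc3ccccc3)nn2)c1` differs from compound 2 in one place: bromo in place of chloro on an aromatic carbon. For the measured compounds named here, no measured step connects these two compounds, so the size of the step in this assay is unknown; a swap of this kind is expected to stay within the usual scatter, in no fixed direction. Compound 3 is expected to give about 5000 nM in this assay, within a range from 800 nM to 40000 nM.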

Compound 3, half-maximal inhibitory concentration: > 50000 nM
Compound 3 ended at the assay's limit (the forecaster's own chance of this, stated with the estimate: 30%); middle value at least 10-fold (1.00 log units) from the limit.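

In this assay compound 3 gives > 50000 nM, which is a limit of the assay and not a number. For the compounds shown here, compound 2 has no single number here, so no step between compound 2 and compound 3 can be read. The compounds shown leave open whether swapping chloro for bromo changes anything, and how strong compound 1 and compound 3 truly are.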